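The source may report more compounds than this note shows. Statements on the series, on what has been measured and on what is new or still open speak of the compounds shown alone.

Measured compounds:
compound 1 `COc1ccc(/C=C2\CN(Cc3cn(Cc4cccc(Cl)c4)nn3)C/C(=C\c3ccc(OC)cc3)C2=O)cc1` — 32500 nM
compound 2 `Cc1ccc(/C=C2\CN(C(=S)SCc3cn(Cc4ccc(F)cc4)nn3)C/C(=C\c3ccc(C)cc3)C2=O)cc1` — 45500 nM
compound 3 `Cc1ccc(/C=C2\CN(C(=S)SCc3cn(Cc4cccc(Cl)c4)nn3)C/C(=C\c3ccc(C)cc3)C2=O)cc1` — only a limit, > 80000 nM

In a functional assay on PC-3 cells (Homo sapiens) for cytotoxicity, read by MTT assay, with a stated time of 24 h (a higher number here means a weaker inhibitor, a lower number a stronger inhibitor), compound 1 gives 32500 nM and compound 2 gives 45500 nM; the two numbers lie within the scatter of each other. For compound 3 this assay returns a limit, > 80000 nM, not a number; the limit of > 80000 nM in this assay, at which 1 of the 3 values shown sits, applies to it.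

Compound 3 and compound 2 differ in one place:
4-fluorophenyl in place of 3-chlorophenyl on a saturated chain carbon bound to an aromatic nitrogen
That change gave an at least 1.7-fold lower number from compound 3 to compound 2 (0.24 log units; that floor lies within the scatter). As far as these compounds go, its true size is unknown, since the starting point is a limit.

Compound 4 `COc1ccc(/C=C2\CN(Cc3cn(Cc4ccc(F)cc4)nn3)C/C(=C\c3ccc(OC)cc3)C2=O)cc1` is not yet measured. It differs from compound 1 in the same way:
4-fluorophenyl in place of 3-chlorophenyl on a saturated chain carbon bound to an aromatic nitrogen
The place lines of the two changes match word for word, so this is the same change made on a second core. How the core of compound 1 differs from the core of compound 3 is not broken down here.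

From compound 1 to compound 4 a step of about a 1.5-fold lower number from compound 1 to compound 4 (0.17 log units; within the scatter) is expected, resting on the step from compound 3 to compound 2 being only a floor. Compound 4 is therefore estimated at 22000 nM, between 10000 nM and 50000 nM.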

Compound 4, half-maximal inhibitory concentration: 67500 nM
The estimate for compound 4 lay 3.1-fold (0.49 log units) below the measured number; measured number outside the range, above it.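

In this assay, 4-fluorophenyl in place of 3-chlorophenyl on a saturated chain carbon bound to an aromatic nitrogen gave a 2.1-fold higher number from compound 1 to compound 4 (0.32 log units; beyond the scatter), so the step seen on one core cannot be assumed to hold on the other: the same change on two cores in this assay, an at least 1.7-fold lower number (0.24 log units; that floor lies within the scatter) from compound 3 to compound 2 and a 2.1-fold higher number (0.32 log units; beyond the scatter) from compound 1 to compound 4, at least 3.6-fold (0.56 log units) apart, beyond the scatter of two such steps. Compound 3 has a limit and not a number, so the earlier step is only a floor: the limit of > 80000 nM in this assay, at which 1 of the 4 values shown sits. These two cores show that the outcome of this change depends on its core in this series, but they do not show which part of the core is responsible or how the change would behave on any further core.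

As far as these compounds go, it remains open how a plain benzyl group or a longer chain carrying an amine would read in this assay at this place on each core. From the compounds shown here alone, a carboxylic acid at the end of such a chain is equally open, as is whether any of these groups would give the same result on both cores.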